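The source may report more compounds than this note shows. Statements on the series, on what has been measured and on what is new or still open speak of the compounds shown alone.

Values in a functional assay on MT4 cells (Homo sapiens) for cytotoxicity; a higher number here means that more compound is tolerated, a lower number that less compound is tolerated:
- Compound 1 `CC(=O)CSc1nc(O)c(C)c(Cc2cccc3ccccc23)n1`: 85000 nM
- Compound 2 `COC(=O)CSc1nc(O)c(C)c(Cc2cccc3ccccc23)n1`: >= 296000 nM
- Compound 3 `CC(=O)CSc1nc(O)c(C(C)C)c(Cc2cccc3ccccc23)n1`: 43000 nM

The entry for compound 2 is a limit of the assay, not a number. Compound 3 stands level with its closest measured neighbour, a 2.0-fold lower number from compound 1 to compound 3 (0.30 log units; within the scatter). Compound 4 `Cc1ccc(C(=O)CSc2nc(O)c(C(C)C)c(Cc3cccc4ccccc34)n2)c(C)c1` carries 2,4-dimethylphenyl in place of methyl on a carbonyl carbon. Going by the values given here, only one measured step alters that same place, an at least 3.4-fold higher number from compound 1 to compound 2 (0.54 log units; beyond the scatter), and it brings in methoxy, not a ring. It shows that this place can move the number, but it does not settle the direction for compound 4. A modest move in this assay toward less tolerated compound is therefore tentatively expected: a 2.0-fold lower number from compound 3 to compound 4 (0.29 log units; within the scatter). For compound 4 the estimated value is 22000 nM, with an expected range of 6000 nM to 90000 nM.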

Compound 4, half-maximal cytotoxic concentration: 27000 nM
Beside the measured number, compound 4's estimate is 1.2-fold (0.09 log units) below it; the measured number falls inside the stated range.
By their numbers in this assay, from the lowest: compounds 4, 3 and 1 (each within the scatter of the next, the first and the last beyond it). At a limit, above all of these: compound 2.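

The earlier step at this carbonyl carbon brought in only methoxy; here an aromatic ring, as 2,4-dimethylphenyl, takes the place of methyl, and in this assay the result is a 1.6-fold lower number from compound 3 to compound 4 (0.20 log units; within the scatter). This place therefore takes a group of eight heavy atoms with a ring, with no change beyond the scatter. Nothing measured here gives a reason for this. As far as these compounds go, whether plain phenyl behaves like 2,4-dimethylphenyl remains open. So does whether an amine or a carboxylic acid at this place would move the number.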